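Cyanophenyl in place of thiazolyl on the saturated carbon

The source may hold more compounds than are shown below. What is called first, only, known or untested is meant among the compounds shown, and "the series" means these compounds.

Compound 1, `Cc1cccc(NC(=O)CN2CCC(c3nccs3)CC2)c1`, gives 62% in a functional assay on HEK293 cells for agonist activity at D(4) dopamine receptor (Homo sapiens), read by FLIPR; a higher number here means a larger maximal response, a lower number a smaller maximal response.
Compound 2, `Cc1cccc(C(=O)NCN2CCC(c3cccc[n+]3[O-])CC2)c1`, gives 77% in this assay.

Compound 1 stands lowest of the two numbers. Compound 2 lies higher by a gap beyond the usual scatter, but the two compounds differ in more than one place, so nothing is known about which of those differences carries the gap.

Compound 3, `Cc1cccc(NC(=O)CN2CCC(c3ccccc3C#N)CC2)c1`, keeps the core of compound 1 and differs from it in one place: 2-cyanophenyl in place of 1,3-thiazol-2-yl on a saturated ring carbon. The group that leaves is a small aromatic ring with two hetero atoms; the group that enters is a larger all-carbon aromatic ring carrying a nitrile.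

Going by the values given here, no measured pair differing in one place exists, so the direction of this change in this assay cannot be read from the data. The expected change for compound 3, a number 5 percentage points higher from compound 1 to compound 3 (within the scatter), is small and within the usual scatter. Compound 3 is therefore estimated at 67%, with a range from 48% to 86%.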

Compound 3, largest response reached (reported as efficacy), in percent of the reference or control that the assay uses: 71%
Beside the measured number, compound 3's estimate is 4 percentage points below it; measured number inside the range.
By their numbers in this assay, from the lowest: compounds 1, 3 and 2 (each within the scatter of the next, the first and the last beyond it).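

In this assay, going by these compounds alone, 2-cyanophenyl in place of 1,3-thiazol-2-yl on the saturated ring carbon gives a number 9 percentage points higher from compound 1 to compound 3 (within the scatter), the first step in this set that changes one place only. The two compounds cannot be told apart here, so at this position, three ring bonds from the ring nitrogen, a six-membered aromatic ring of carbon only that carries a nitrile serves as well as a five-membered aromatic ring with 2 hetero atoms, at least for the maximal response on this pair. No measurement at hand accounts for this match in response between two such different groups.

As far as these compounds go, what the nitrile itself adds remains open: a plain phenyl ring on the same ring carbon would separate its part from that of the carbon ring, and an amine or a methoxy group in the nitrile's stead would test how far that group can be exchanged. Compound 2 differs from both other compounds in more than one place, so its steps cannot be read, and how the linking amide and the group on the saturated ring carbon each bear on the response stays unresolved.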